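Swapping a furan for phenyl on a nucleoside-like core

A few compounds are considered here, and "the series" means these few. Any claim that something is new, unique, unknown or untested is made for them only; others in the source may bear on it.

The set is small. Compound 1 `O=c1[nH]cnc2c1c(-c1ccoc1)cn2[C@@H]1O[C@H](CO)[C@@H](O)[C@H]1O` carries a furan-3-yl group on its shared core; in a functional assay on K562 cells (Homo sapiens), read by MTT assay, with a stated time of 72 h (on this read-out higher numbers stand for weaker inhibition and lower numbers for stronger inhibition), compound 1 gives 12500 nM, the lowest of the two numbers in hand. Compound 3 `Nc1nc2c(c(-c3ccoc3)cn2[C@@H]2O[C@H](CO)[C@@H](O)[C@H]2O)c(=O)[nH]1` gives 19600 nM in this assay, and the step of a 1.6-fold higher number from compound 1 to compound 3 (0.20 log units; within the scatter) is therefore not a real change. Compound 2 `COc1nc(N)nc2c1c(-c1ccsc1)cn2[C@@H]1O[C@H](CO)[C@@H](O)[C@H]1O` reaches only a limit of this assay, > 20000 nM, and so adds no number (the limit of > 20000 nM in this assay, at which 1 of the 3 values shown sits).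

The change that leads from compound 1 to compound 4 `O=c1[nH]cnc2c1c(-c1ccccc1)cn2[C@@H]1O[C@H](CO)[C@@H](O)[C@H]1O` is phenyl in place of furan-3-yl on an aromatic carbon. Among the compounds with values here, no measured step in the set touches this position: the one step in hand, from compound 1 to compound 3, alters a different group, and compound 2 differs from the others in more than one place. There is thus no direct guide. With nothing beyond the scatter shown by the single comparable step, compound 4 is expected to sit close to compound 1, with a step of no change at the digits printed from compound 1 to compound 4 (within the scatter) that need not exceed the scatter. Compound 4 is estimated at 12500 nM, within a range of 4000 nM to 40000 nM.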

Compound 4, half-maximal inhibitory concentration: > 20000 nM
Compound 4: only a limit was reported; the forecaster's own chance of this, stated with the estimate: 35%; at least 1.6-fold (0.20 log units) between middle value and limit.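

At this position, on an aromatic carbon two ring bonds from the ring nitrogen, the set now holds its first direct comparison, and in this assay it reads as an at least 1.6-fold higher number from compound 1 to compound 4 (0.20 log units; that floor lies within the scatter). The step fixes no real change, yet it has no upper end, so phenyl in place of furan-3-yl may be a small step or a large one. Compound 4 stands at a limit of the assay and not at a number, and such limits now make up a sizeable share of what is shown: the limit of > 20000 nM in this assay, at which 2 of the 4 values shown sit.

As far as these compounds go, it remains open whether an amine or a carboxylic acid carried on the ring at this position, or a longer chain in its place, would give a lower number than compound 1 does. Also open, from the compounds shown here alone, is how far the number for compound 4 actually lies from that of compound 1.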